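The source may report more compounds than this note shows. Statements on the series, on what has been measured and on what is new or still open speak of the compounds shown alone.

In a functional assay on MCF7 cells (Homo sapiens) for cytotoxicity, read by neutral red uptake, with a stated time of 3 days (a lower number here means a stronger inhibitor, a higher number a weaker inhibitor), compound 1 `Cc1c(F)c(N)c2c(=O)cc(-c3ccc(N)c(F)c3)oc2c1F` gives 13 nM, while compound 2 `CCCCCCCCCC(=O)OCc1c(F)c(N)c2c(=O)cc(-c3ccc(N)c(F)c3)oc2c1F` gives 100 nM, the higher of the two numbers and beyond the scatter from compound 1. Compound 3 `CN(C)CCCOCc1c(F)c(N)c2c(=O)cc(-c3ccc(N)c(F)c3)oc2c1F` has 3-(dimethylamino)propyl in place of nonylcarbonyl on an oxygen on a saturated carbon. Going by the values given here, no measured pair shows this change, so the expectation rests on these two values alone. With compound 1 at 13 nM, a moderate move toward lower numbers in this assay is expected. The estimated step is a 2.5-fold lower number from compound 2 to compound 3 (0.40 log units; beyond the scatter). For compound 3 the expected value is 40 nM, with an estimated range of 8 nM to 200 nM.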

Compound 3, half-maximal inhibitory concentration: > 10000 nM
Compound 3: only a limit was reported; the forecaster's own chance of this, stated with the estimate: 3%; middle value at least 250-fold (2.39 log units) away from the limit.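

Compound 2 had shown that a long acyl group on this oxygen still leaves a measurable number of 100 nM, but compound 3 shows that the group entering here can decide whether any number is reached at all. In this assay, 3-(dimethylamino)propyl in place of nonylcarbonyl gives an at least 100-fold higher number from compound 2 to compound 3 (2.00 log units; beyond the scatter), and 3-(dimethylamino)propoxy in place of hydrogen gives an at least 760-fold higher number from compound 1 to compound 3 (2.88 log units; beyond the scatter). The > 10000 nM of compound 3 is a limit and not a number: the limit of > 10000 nM in this assay, at which 1 of the 3 values shown sits.

The compounds shown leave open whether these steps go with the amine or with the loss of the ester carbonyl, as the two change together. An ester ending in an amine, or a plain alkyl ether with a longer chain, would separate them.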